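The compounds below may be only part of what the source reports. "The series", "measured", "known", "first", "only" and "open" are said of these compounds alone.

In a functional assay on PBMC cells (Homo sapiens) for inhibition, read by HTRF, with stated times of 15 min and 24 h; a lower number here means a stronger inhibitor, a higher number a weaker inhibitor:
- Compound 1 `O=C(Nc1ccc2c(c1)B(O)OC2)c1ccccc1C(F)(F)F`: 2100 nM
- Compound 2 `O=C(Nc1ccc2c(c1)B(O)OC2)c1ccc(C(F)(F)F)cc1F`: > 100000 nM (a limit of the assay)

Compound 2 gives only a limit, > 100000 nM, and no number. Compound 3 `O=C(Nc1ccc2c(c1)B(O)OC2)c1ccc(C(F)(F)F)cc1C(F)(F)F` has trifluoromethyl in place of fluoro on an aromatic carbon, ortho to a large group: trifluoromethyl in place of fluoro on an aromatic carbon. For the measured compounds named here, no measured step shows the size of this change in this assay. Compound 1 also carries a trifluoromethyl group and gives 2100 nM, and on that ground compound 3 is expected to be the stronger inhibitor of the pair. The expected change is an at least 5.0-fold lower number from compound 2 to compound 3 (0.69 log units; beyond the scatter). The estimate for compound 3 is 20000 nM, with an expected range of 3000 nM to 100000 nM.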

Compound 3, half-maximal inhibitory concentration: 5300 nM
Compound 3: middle estimate off by 3.8-fold (0.58 log units), on the high side, within the range that was stated.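

In this assay, trifluoromethyl in place of fluoro, ortho to a large group, gives an at least 18-fold lower number from compound 2 to compound 3 (1.27 log units; beyond the scatter), so the group at this position separates an active compound from an inactive one within this pair. The size of that step is open-ended, as compound 2 gives only a limit and not a number: the limit of > 100000 nM in this assay, at which 1 of the 3 values shown sits. Trifluoromethyl in place of hydrogen gives a 2.5-fold higher number from compound 1 to compound 3 (0.40 log units; beyond the scatter), a modest loss set against that large gain. Going by these compounds, whether a chlorine atom, a methyl group or an amine at this position would match trifluoromethyl remains open.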